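A few compounds are considered here, and "the series" means these few. Any claim that something is new, unique, unknown or untested is made for them only; others in the source may bear on it.

Compound 1 `CNC(=O)c1c(O)c2cccnc2n(-c2ccccc2)c1=O` gives 21% in a functional assay on the whole organism for inhibition, with Rattus norvegicus as the target, read by cytopathic effect and paw edema, at a dose of 100 mg/kg by the oral route (on this read-out lower numbers stand for less inhibition and higher numbers for more inhibition at the one dose given (going by the name of the read-out)), the highest of the three numbers recorded. Compound 2 `O=C(Nc1ccccc1)c1c(O)c2cccnc2n(-c2ccccc2)c1=O` gives -15% in this assay, and compound 3 `COc1cccc(NC(=O)c2c(O)c3cccnc3n(-c3ccccc3)c2=O)c1` gives 20.7%. The step of a number 36 percentage points lower from compound 1 to compound 2 (beyond the scatter) is large, whereas the step of a number 0.3 percentage points lower from compound 1 to compound 3 (within the scatter) lies within the scatter, and the step of a number 35.7 percentage points higher from compound 2 to compound 3 (beyond the scatter) is again large. Compound 4 `O=C(Nc1cccc(Cl)c1)c1c(O)c2cccnc2n(-c2ccccc2)c1=O` has not yet been measured in this assay. It differs from compound 1 as follows: 3-chlorophenyl in place of methyl on an amide-type nitrogen. Both measured steps from compound 1 bear on this change, since each puts an aryl group on the same amide-type nitrogen, yet they point in opposite directions: the unsubstituted phenyl lost heavily, while the 3-methoxyphenyl held level. A 3-chlorophenyl carries its substituent where the methoxy of compound 3 sits, but chlorine is not methoxy, so the outcome is uncertain and a moderate loss is expected as the middle case, a number 16 percentage points lower from compound 1 to compound 4 (beyond the scatter). Compound 4 is therefore estimated at 5% in this assay, within a range from -25% to 30%.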

Compound 4, a percentage reported as inhibition, in the whole organism at one dose (the size of the read-out at that dose, not a potency): 13.4%
Beside the measured number, compound 4's estimate is 8.4 percentage points below it; the range from low to high includes it.
By their numbers in this assay, from the lowest: compound 2; then compounds 4, 3 and 1 (each within the scatter of the next).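

In this assay a substituted aryl group on the amide-type nitrogen again costs nothing measurable against methyl, as a number 7.6 percentage points lower from compound 1 to compound 4 (within the scatter) shows, and a number 7.3 percentage points lower from compound 3 to compound 4 (within the scatter) means that chloro and methoxy on this ring cannot be told apart. Compound 2, with its unsubstituted phenyl, therefore stands alone among the aryl amides shown, and a number 28.4 percentage points higher from compound 2 to compound 4 (beyond the scatter) shows that a chloro on that ring also lifts the number, although this step is modest, not large. No measurement offered here explains why compound 2 alone falls away.

As far as these compounds go, whether an amine or a carboxylic acid on the same aryl ring would hold the number stays open, as does the effect of a longer chain in place of methyl on the amide-type nitrogen. With only one dose given, the potency of these compounds also remains open.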